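The source may hold more compounds than are shown below. What is called first, only, known or untested is meant among the compounds shown, and "the series" means these compounds.

Measured compounds:
- compound 1 `CC(C)(C)OC(=O)N/N=C/c1c(N)ncnc1Oc1ccc(NC(=O)C2(C(=O)Nc3ccc(F)cc3)CC2)cc1F`: 3.7
- compound 2 `CNc1ncnc(Oc2ccc(NC(=O)C3(C(=O)Nc4ccc(F)cc4)CC3)cc2F)c1/C=N/OC`: 3.52

In a physicochemical assay for lipophilicity, using the shake flask method (on this read-out lower numbers stand for lower lipophilicity and higher numbers for higher lipophilicity), compound 1 gives 3.7 and compound 2 gives 3.52. The two numbers lie within the usual scatter of each other, so neither compound can be called the more lipophilic of the pair; compound 1 merely holds the higher of the two numbers as read.

Compound 3 `Nc1ncnc(Oc2ccc(NC(=O)C3(C(=O)Nc4ccc(F)cc4)CC3)cc2F)c1/C=N/OC1CCCC1` has not yet been measured in this assay. It is reached from compound 1 by a single change: cyclopentyloxy in place of (tert-butoxycarbonyl)amino on a double-bonded nitrogen. For the measured compounds named here, no measured pair shows this step, so its size is not known from data. The departing group carries a hydrogen-bond donor and two acceptors, the entering group no donor and one acceptor, and a five-membered carbon ring enters. An upward step from compound 1 to compound 3 of a number 0.60 log units higher from compound 1 to compound 3 (beyond the scatter) is expected, beyond the scatter. Compound 3 is therefore estimated at 4.3, with a range from 3.7 to 4.9.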

Compound 3, partition coefficient: 4.27
For compound 3 the middle estimate is 0.03 log units above the measured one; the measured number falls inside the stated range.
By their numbers in this assay, from the lowest: compounds 2 and 1 (each within the scatter of the next); then compound 3.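

In this assay, for the compounds shown here, cyclopentyloxy in place of (tert-butoxycarbonyl)amino on a double-bonded nitrogen gives a number 0.57 log units higher from compound 1 to compound 3 (beyond the scatter), the only step so far that can be read at this position. The read-out therefore responds to a change at this place, although this one step combines several differences: a hydrogen-bond donor and a double bond outside aromatic rings leave, and a five-membered non-aromatic ring of carbon only enters. No measured information on hand accounts for the size of this step.

The shares of these differences in the step remain undivided, and an open-chain pentyloxy group at the same place would be needed to set the ring apart from the rest of the change. From the compounds shown here alone, how a carboxylic acid or an amine at this place would read also remains open.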